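Methoxy removal on the aryl ring of the pyrazole chalcones

A few compounds are considered here, and "the series" means these few. Any claim that something is new, unique, unknown or untested is made for them only; others in the source may bear on it.

Two compounds of this series have been run in a functional assay on HCC 2998 cells (Homo sapiens) for cytotoxicity, read by sulforhodamine B assay, with a stated time of 48 h, tested at 10 uM; a lower number here means a stronger effect, a higher number a weaker effect of the compound at the concentration tested. Compound 1 `COc1ccc(-c2cc(/C=C/C(=O)c3ccc(N)cc3)[nH]n2)cc1` gives -90% in this assay. Compound 2 `COc1cc(-c2cc(/C=C/C(=O)c3ccc(N)cc3)[nH]n2)cc(OC)c1OC` gives -86% in this assay; its number and that of compound 1 lie within the usual scatter of each other, so the two are not separated and neither can be called the stronger on these data.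

Compound 3 `COc1ccc(-c2cc(/C=C/C(=O)c3ccc(N)cc3)[nH]n2)cc1OC` has not yet been measured in this assay. It differs from compound 2 at one place: hydrogen in place of methoxy on an aromatic carbon. Among the compounds with values here, no measured pair shows this particular change, so its effect is not known from the data. Since compound 1 and compound 2 sit together despite different numbers of methoxy groups, the change from compound 2 to compound 3 is expected to give no step beyond the scatter, a number 2 percentage points lower from compound 2 to compound 3 (within the scatter). Compound 3 is accordingly estimated at -88% in this assay, with a range from -98% to -72%.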

Compound 3, a percentage reported as activity, at one concentration (the size of the read-out at that concentration, not a potency): -75%
The estimate for compound 3 lay 13 percentage points below the measured number, within the range that was stated.
By their numbers in this assay, from the lowest: compounds 1 and 2 (each within the scatter of the next); then compound 3.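

In this assay, hydrogen in place of methoxy on an aromatic carbon, ortho to a methoxy group, gives a number 11 percentage points higher from compound 2 to compound 3 (beyond the scatter), so the effect is not indifferent to the change at this position, as the close numbers of the earlier pair might have suggested. The reverse kind of change, methoxy in place of hydrogen on an aromatic carbon, gives a number 15 percentage points higher from compound 1 to compound 3 (beyond the scatter), so the effect does not follow the number of methoxy groups: the weaker number of compound 3 is set against both neighbours, one with more methoxy groups and one with fewer. Nothing at hand accounts for either step.

Open, going by these compounds, is how a hydroxyl group, an ethoxy group or a chlorine atom would read at this position. Also open, on these data alone, is whether the same pattern appears on the other methoxy-bearing carbons of this aromatic ring.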